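A few compounds are considered here, and "the series" means these few. Any claim that something is new, unique, unknown or untested is made for them only; others in the source may bear on it.

Measured so far in a functional assay on Ramos cells (Homo sapiens) for antiproliferative activity, read by CCK-8 assay, with a stated time of 24 h; a lower number here means a stronger inhibitor, a higher number a weaker inhibitor:
compound 1 `C=CC(=O)Nc1cccc(Nc2nc(Cl)nc(Nc3ccc(Oc4ccccc4)cc3)n2)c1` gives 12300 nM;
compound 2 `C=CC(=O)Nc1cccc(Nc2nc(N)nc(Nc3ccc(OCCOC)cc3)n2)c1` gives 18900 nM.

Compound 2 carries the higher of the two numbers in this assay, but its gap to compound 1 is within the scatter, so no order is read between them. Going by the values given here, compound 1 and compound 2 differ in more than one place, so no single step is drawn from that pair. Compound 3 `C=CC(=O)Nc1cccc(Nc2nc(N)nc(Nc3ccc(Oc4ccccc4)cc3)n2)c1` is the unmeasured member; against compound 2 the change is phenyl in place of 2-methoxyethyl on an oxygen on an aromatic ring. Among the compounds with values here, no measured step of this kind exists, so no shift beyond the scatter is expected in either direction. Compound 3 is estimated at 15000 nM, with a range of 7000 nM to 35000 nM. The step of a 1.3-fold lower number from compound 2 to compound 3 (0.10 log units; within the scatter) is expected to stay within the scatter.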

Compound 3, half-maximal inhibitory concentration: 20000 nM
For compound 3 the middle estimate is 1.3-fold (0.12 log units) below the measured one; measured number inside the range.
By their numbers in this assay, from the lowest: compounds 1, 2 and 3 (each within the scatter of the next).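

In this assay, a 1.1-fold higher number from compound 2 to compound 3 (0.02 log units; within the scatter) shows that, with amino held on the shared core, phenyl and 2-methoxyethyl on an oxygen on an aromatic ring are not told apart. Going by these compounds alone, with phenoxy held, a 1.6-fold higher number from compound 1 to compound 3 (0.21 log units; within the scatter) gives the first single-place reading of amino in place of chloro on an aromatic carbon, and these two groups are not told apart either. No supporting measurement offers a reason for either result.

Open, going by these compounds, is whether a longer chain ending in an amine or a carboxylic acid on that oxygen would give a step beyond the scatter. Also open, on these data alone, is whether a methyl group on that aromatic carbon would do so.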